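The compounds below may be only part of what the source reports. "The series", "measured", "known", "first", "only" and "open" are said of these compounds alone.

Compound 1 `CC(C)=CC[C@@H](OC[C@H](C)O)C1=CC(=O)c2c(O)ccc(O)c2C1=O` carries a 2-hydroxypropyl group on an oxygen on a saturated carbon of the shared core. In a functional assay on HeLa cells (Homo sapiens) for cytotoxicity, read by MTT assay (on this read-out lower numbers stand for stronger inhibition and higher numbers for weaker inhibition), compound 1 gives 40300 nM. Compound 2 `CC[C@](C)(O)CC(=O)O[C@H](CC=C(C)C)C1=CC(=O)c2c(O)ccc(O)c2C1=O` gives 30200 nM in this assay, and compound 3 `CCC(CO[C@H](CC=C(C)C)C1=CC(=O)c2c(O)ccc(O)c2C1=O)OC(C)=O` gives 44000 nM. Among these three numbers compound 1 stands second highest. Its nearest neighbour is compound 3, with a 1.1-fold higher number from compound 1 to compound 3 (0.04 log units; within the scatter); its furthest is compound 2, with a 1.3-fold lower number from compound 1 to compound 2 (0.13 log units; within the scatter). The remaining pair shows a 1.5-fold higher number from compound 2 to compound 3 (0.16 log units; within the scatter). All three compounds therefore sit within the usual scatter of one another, and no order can be read among them.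

Compound 4 `CC[C@@](C)(O)CC(=O)O[C@H](CC=C(C)C)C1=CC(=O)c2c(O)ccc(O)c2C1=O` differs from compound 1 in a single place: (2-hydroxy-2-methylbutyl)carbonyl in place of 2-hydroxypropyl on an oxygen on a saturated carbon. The same change in words, at the same place, separates compound 1 from compound 2; compound 4 and compound 2 differ only in the defined stereocentre of the entering group. The measured step that bears on it is therefore a 1.3-fold lower number from compound 1 to compound 2 (0.13 log units; within the scatter), which lies within the scatter, and the steps involving compound 3 give no hint of a larger movement. The expected step in this assay is accordingly a 1.3-fold lower number from compound 1 to compound 4 (0.10 log units; within the scatter), which is no change beyond the scatter. Compound 4 is thus estimated at 32000 nM, expected to fall between 15000 nM and 65000 nM.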

Compound 4, half-maximal inhibitory concentration: 17900 nM
Compound 4: middle estimate off by 1.8-fold (0.25 log units), on the high side; low and high end bracket the measured number.
By their numbers in this assay, from the lowest: compounds 4, 2, 1 and 3 (each within the scatter of the next, the first and the last beyond it).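

In this assay, within the data shown here, the (2-hydroxy-2-methylbutyl)carbonyl group on this oxygen now produces the first steps beyond the scatter, though both are modest: a 2.3-fold lower number from compound 1 to compound 4 (0.35 log units; beyond the scatter) and a 2.5-fold lower number from compound 3 to compound 4 (0.39 log units; beyond the scatter). Compound 2 carries a group of the same name, yet its steps to compound 1 and compound 3 stay within the scatter, so this separation appears with only one of the two drawn configurations, even though a 1.7-fold lower number from compound 2 to compound 4 (0.23 log units; within the scatter) does not itself separate the two configurations. The configuration of this stereocentre is therefore the only variable in that last comparison, and its effect cannot be told from the scatter, a reading that rests on one structural fact: the fact that compounds 2 and 4 differ only in the configuration as drawn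

The compounds shown leave open whether an amine or a carboxylic acid in this group, or a longer chain, would move the number further than these modest steps. They also leave open whether the same change on this oxygen would act in the same way on a different core.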